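Swapping a methoxy for hydrogen on the shared core

The source may report more compounds than this note shows. Statements on the series, on what has been measured and on what is new or still open speak of the compounds shown alone.

Measured so far in a functional assay on A549 cells (Homo sapiens) for antiproliferative activity, read by sulforhodamine B assay, with a stated time of 48 h; a lower number here means a stronger inhibitor, a higher number a weaker inhibitor
- compound 1 `COc1cc(OC)c2sc(-c3ccc(N/C=C\C(=O)c4cc(OC)c(OC)c(OC)c4)cc3)nc2c1` gives 21800 nM
- compound 2 `COc1cc(OC)c2sc(-c3ccc(N/C=C\C(=O)c4ccc(OC)c(F)c4)c(C)c3)nc2c1` gives 15300 nM
- compound 3 `COc1ccc(C(=O)/C=C\Nc2ccc(-c3nc4cc(OC)c(OC)c(OC)c4s3)cc2)cc1F` gives 15500 nM

These three numbers sit close together. Compound 3 lies within the usual scatter of repeated measurements of both other compounds, so the data offer no ranking among them.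

The next compound to be tested is compound 4 `COc1cc(OC)c2sc(-c3ccc(N/C=C\C(=O)c4ccc(OC)c(F)c4)cc3)nc2c1`. It differs from compound 3 at a single place on the core, with hydrogen in place of methoxy on an aromatic carbon. Going by the values given here, no two measured compounds differ in only one place, so nothing here shows directly what this change does. The expectation therefore starts from compound 3 at 15500 nM, and no shift beyond the scatter is expected in this assay. The expected change is a 1.0-fold lower number from compound 3 to compound 4 (0.01 log units; within the scatter). For compound 4 the estimated value is 15000 nM, with an expected range from 6000 nM to 33000 nM.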

Compound 4, half-maximal inhibitory concentration: 5300 nM
For compound 4 the middle estimate is 2.8-fold (0.45 log units) above the measured one, and the stated range ends above it.
By their numbers in this assay, from the lowest: compound 4; then compounds 2, 3 and 1 (each within the scatter of the next).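

In this assay, going by these compounds alone, hydrogen in place of methoxy on an aromatic carbon of the core gives a 2.9-fold lower number from compound 3 to compound 4 (0.47 log units; beyond the scatter) and is the first single change at this position whose size can be read. Compound 4 also completes two other single-place comparisons: removing the methyl group from its aromatic carbon, which then carries hydrogen, gives a 2.9-fold lower number from compound 2 to compound 4 (0.46 log units; beyond the scatter) and 3-fluoro-4-methoxyphenyl in place of 3,4,5-trimethoxyphenyl on a carbonyl carbon gives a 4.1-fold lower number from compound 1 to compound 4 (0.61 log units; beyond the scatter) in this same assay. Nothing measured here explains why any of these changes lowers the number.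

The compounds shown leave open how other groups at this core position, such as an amine, a hydroxyl or an ethoxy group, would compare with hydrogen and methoxy. From the compounds shown here alone, each change is also seen only once, so whether it would give a similar step on a different partner structure remains unknown.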